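Azetidinyl to chloroanilino on the shared core

The compounds below may be only part of what the source reports. "The series", "measured", "known", "first", "only" and "open" are said of these compounds alone.

Measured compounds:
compound 1, `Cc1ccc(NC2=CC(=O)c3c(nc4n3[C@H]3OC[C@@H](O)[C@H]3OC4)C2=O)cc1`, > 4000 nM in a functional assay on ECa-109 cells for inhibition, with ECa-109 cell line (Homo sapiens) as the target, read by sulforhodamine B assay; on this read-out lower numbers stand for stronger inhibition and higher numbers for weaker inhibition
compound 2, `O=C1C(N2CCC2)=CC(=O)c2c1nc1n2[C@H]2OC[C@@H](O)[C@H]2OC1`, > 16000 nM

Compound 1 gives only a limit of the assay in this assay, namely > 4000 nM. Compound 2 likewise gives only a limit in this assay, > 16000 nM. Among the compounds with values here, both values are limits, so compound 2 cannot be placed against compound 1 on the numbers; the only step with a measured pair, a step that the two limits leave unreadable from compound 1 to compound 2, is unreadable for the same reason, as the limit of > 16000 nM in this assay, at which 1 of the 2 values shown sits, and the limit of > 4000 nM in this assay, at which 1 of the 2 values shown sits, show.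

Compound 3, `O=C1C(Nc2cccc(Cl)c2)=CC(=O)c2c1nc1n2[C@H]2OC[C@@H](O)[C@H]2OC1`, differs from compound 2 by (3-chlorophenyl)amino in place of azetidin-1-yl on a double-bonded ring carbon. Compound 3 thus carries an arylamino group at the double-bonded ring carbon, as compound 1 does, rather than the azetidin-1-yl of compound 2. Within the data shown here, no measured step gives a readable size for this kind of change, so no direction can be taken from the series beyond the fact that compound 1, the other arylamino compound, sits at a limit of this assay.

Compound 3 is therefore expected to stay weak, with an estimated 10000 nM between 2000 nM and 50000 nM, corresponding to an expected step of an at least 1.6-fold lower number from compound 2 to compound 3 (0.20 log units; that floor lies within the scatter), and a further limit rather than a number is the likeliest outcome.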

Compound 3, half-maximal inhibitory concentration: 3080 nM
Estimate against measurement, compound 3: 3.2-fold (0.51 log units) above; the range from low to high includes it.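

In this assay, compound 3 gives the only actual number among the three compounds shown, so this double-bonded ring carbon can carry a group that brings the read-out within measurable range on the shared core. Within the data shown here, putting (3-chlorophenyl)amino in place of azetidin-1-yl gives an at least 5.1-fold lower number from compound 2 to compound 3 (0.71 log units; beyond the scatter), the first step at this position with a readable floor, and that floor already clears the scatter, although the full size stays unknown with compound 2 held at a limit. Within the arylamino pair, 3-chlorophenyl in place of 4-methylphenyl on the amine nitrogen gives an at least 1.2-fold lower number from compound 1 to compound 3 (0.11 log units; that floor lies within the scatter), a floor that does not separate the two aryl groups, and the step from compound 1 to compound 2 remains unreadable, as both of its values are limits.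

The compounds shown do not tell whether the chlorine, the aromatic ring or the amine hydrogen carries the difference from compound 2, since the aromatic ring and the amine hydrogen enter together and the only chlorine-bearing compound also differs from compound 1 in the ring substituent's place. A plain phenylamino group, a benzylamino group or a morpholin-4-yl group on the same carbon would help to separate these parts.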